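Trimming the saturated chain of compound 1

This account rests on a few compounds, and the source may have more. Where it says the series, first, only, none or still open, it means among the compounds named here.

In a functional assay on MCF7 cells (Homo sapiens) for inhibition, read by fluorescence, with a stated time of 72 h (a lower number here means a stronger inhibitor of growth, a higher number a weaker inhibitor of growth), compound 1 `CCCCCCn1cnc2c(Nc3ccc(Cl)cc3)nc(N[C@H]3CC[C@H](N)CC3)nc21` gives 4200 nM. Compound 2 `CCCCCCn1cnc2c(Nc3ccc(O)cc3)nc(N[C@H]3CC[C@H](N)CC3)nc21` gives 3500 nM. Compound 3 `CCCCCCn1cnc2c(Nc3cccc(Cl)c3)nc(N[C@H]3CC[C@H](N)CC3)nc21` gives 2700 nM. All three numbers lie within the scatter of one another, so compound 1 stands level with the other two.

Compound 4 `CCCCn1cnc2c(Nc3ccc(Cl)cc3)nc(N[C@H]3CC[C@H](N)CC3)nc21` keeps the core of compound 1 and its 4-chlorophenyl group and differs only in the saturated chain: hydrogen in place of ethyl on a saturated chain carbon, four bonds along the chain from an aromatic nitrogen. In words, this is hydrogen in place of ethyl on a saturated chain carbon, four bonds along the chain from an aromatic nitrogen.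

Going by the values given here, no measured step touches that chain. The three available steps all change the group on the aromatic ring: a 1.2-fold lower number from compound 1 to compound 2 (0.08 log units; within the scatter), a 1.6-fold lower number from compound 1 to compound 3 (0.19 log units; within the scatter) and a 1.3-fold lower number from compound 2 to compound 3 (0.11 log units; within the scatter). They bear on the new change only indirectly, showing a flat response at another place in the structure. The effect of the chain itself remains unmeasured, so the range has to stay wide.

No step beyond the scatter is expected in this assay, and no direction can be argued from these data. The expected step is a 1.1-fold higher number from compound 1 to compound 4 (0.03 log units; within the scatter). Compound 4 is estimated at 4500 nM, with an expected range of 1800 nM to 11000 nM.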

Compound 4, concentration for 50% growth inhibition: 2100 nM
Estimate against measurement, compound 4: 2.1-fold (0.33 log units) above, and the stated range covers the measured number.
By their numbers in this assay, from the lowest: compounds 4, 3, 2 and 1 (each within the scatter of the next).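

In this assay, the chain position now has a measured step of its own: hydrogen in place of ethyl, four bonds along the chain from an aromatic nitrogen, gives a 2.0-fold lower number from compound 1 to compound 4 (0.30 log units; within the scatter). This position therefore joins the group on the aromatic ring as a place where the steps shown stay within the scatter, and the ethyl can leave the chain with no change in growth inhibition that these data can resolve. No measurement shown here speaks to why the response at this position is flat.

Open, as far as these compounds go, is whether the response stays flat over a wider range of chains: a propyl or methyl group on the aromatic nitrogen, a longer chain, or a chain ending in an amine or a carboxylic acid might each give a step beyond the scatter. Also open is whether the butyl chain of compound 4 behaves the same way alongside the 3-chlorophenyl group of compound 3 or the 4-hydroxyphenyl group of compound 2, as the only chain step shown carries the 4-chlorophenyl group.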